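This account rests on a few compounds, and the source may have more. Where it says the series, first, only, none or still open, it means among the compounds named here.

Working notes on the series, read in a functional assay on MT4 cells (Homo sapiens) for cytotoxicity; a higher number here means a weaker inhibitor, a lower number a stronger inhibitor. Compound 1 `N#Cc1c(N)cccc1Sc1ccc(Cl)cc1` gives 113000 nM, and compound 3 `Cc1cc(O)cc(S(=O)(=O)c2cccc(N)c2C#N)c1` gives 167000 nM, so these two numbers lie within the usual scatter of each other. Compound 2 `N#Cc1c(N)cccc1[S+]([O-])c1ccc(Br)cc1` reads > 200000 nM, which is a limit of the assay and not a number. For the measured compounds named here, compound 3 therefore stands level with compound 1, the only other compound with a measured number.

Compound 4 `CCOc1cc(C)cc(S(=O)(=O)c2cccc(N)c2C#N)c1` is compound 3 with ethyl in place of hydrogen on an oxygen on an aromatic ring, or hydroxy to ethoxy. Going by the values given here, no measured pair shows this change on its own, so the expectation rests on compound 3 at 167000 nM and on the closeness of compound 1 at 113000 nM. The expected step of a 1.5-fold lower number from compound 3 to compound 4 (0.18 log units; within the scatter) is small, leaning to a lower number and not expected to go beyond the scatter. For compound 4 the estimated value in this assay is 110000 nM. The expected range for compound 4 runs from 40000 nM to 200000 nM.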

Compound 4, half-maximal inhibitory concentration: 9000 nM
The estimate for compound 4 lay 12-fold (1.09 log units) above the measured number; the whole stated range lies above it.
By their numbers in this assay, from the lowest: compound 4; then compounds 1 and 3 (each within the scatter of the next). At a limit, above all of these: compound 2.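

In this assay, the oxygen on the aromatic ring proves to be a place where a single change moves the number well beyond the scatter, with ethyl in place of hydrogen giving a 19-fold lower number from compound 3 to compound 4 (1.27 log units; beyond the scatter). For the compounds shown here, no earlier pair differed in one place, so this is the only single change that can be read so far. It shows that hydroxy to ethoxy alone, with the rest of compound 3 unchanged, is enough for a large step toward a lower number.

From the compounds shown here alone, whether this step belongs to ethyl itself or would also follow from methoxy, from a longer chain such as propoxy, or from an amine at this place remains open. Nothing measured in the series accounts for the size of the step.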